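Oxadiazole substituent variation in the hydroxamate series

This account rests on a few compounds, and the source may have more. Where it says the series, first, only, none or still open, it means among the compounds named here.

Compound 3 `O=C(NO)c1cccc(OCc2ccc(-c3noc(-c4ccccc4F)n3)cc2)c1` gives only a limit in an assay on isolated protein for inhibition of sphingomyelin phosphodiesterase (Homo sapiens), read by fluorescence, with a stated time of 30 min; a lower number here means a stronger inhibitor, a higher number a weaker inhibitor: compound 3 reads > 100000 nM, a limit of the assay and not a number. Compound 1 `O=C(NO)c1cccc(OCc2ccc(/C=C/c3ccccc3)cc2)c1` likewise sits at a limit in this assay, with > 100000 nM. Compound 2 `CCc1nc(-c2ccc(COc3cccc(C(=O)NO)c3)cc2)no1` gives a number in this assay, 34700 nM. The measured steps are an at least 2.8-fold lower number from compound 1 to compound 2 (0.45 log units; beyond the scatter) and an at least 2.8-fold higher number from compound 2 to compound 3 (0.45 log units; beyond the scatter); both run against the limit, so their true size is open, and compound 3 stands at the limit of > 100000 nM in this assay, at which 2 of the 3 values shown sit.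

Compound 4 `O=C(NO)c1cccc(OCc2ccc(-c3noc(CCc4ccccc4)n3)cc2)c1` carries phenethyl in place of 2-fluorophenyl on an aromatic carbon. Going by the values given here, the step that bears on it is the one from compound 2 to compound 3, an at least 2.8-fold higher number from compound 2 to compound 3 (0.45 log units; beyond the scatter), in which the ethyl on the five-membered ring gave the only numerical value of the three. Phenethyl keeps a chain at that position, so a return toward the value of compound 2 is expected, though compound 3 starting at a limit leaves the step size uncertain; the expected step is an at least 1.4-fold lower number from compound 3 to compound 4 (0.15 log units; that floor lies within the scatter). Compound 4 is estimated at 70000 nM, within 25000 nM to 250000 nM.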

Compound 4, half-maximal inhibitory concentration: 1730 nM
Compound 4: middle estimate off by 40-fold (1.61 log units), on the high side; the measured number lies below the stated range.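

In this assay, phenethyl in place of 2-fluorophenyl gives an at least 57-fold lower number from compound 3 to compound 4 (1.76 log units; beyond the scatter), so an aromatic ring at this position is compatible with inhibition when a saturated chain carries it. Phenyl on the saturated chain gives a 20-fold lower number from compound 2 to compound 4 (1.30 log units; beyond the scatter), so the added ring does more than preserve the value of the ethyl group. The full size of the change from 2-fluorophenyl remains open because compound 3 stands at a limit: the limit of > 100000 nM in this assay, at which 2 of the 4 values shown sit.

From the compounds shown here alone, whether the gain depends on chain length remains open, and benzyl or 3-phenylpropyl would test this, as would an amine or a carboxylic acid on the terminal ring. The effect of the fluorine in compound 3 also remains unseparated from that of its directly attached ring, and unsubstituted phenyl would provide that comparison.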